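Turning the Fluoromethylethyl Carbamate Over

The source may hold more compounds than are shown below. What is called first, only, known or untested is meant among the compounds shown, and "the series" means these compounds.

Measured so far:
compound 1 `Cc1nc(S(C)(=O)=O)ccc1Oc1ncnc(OC2CCN(C(=O)OC3CCC3)CC2)c1F` — 167 nM
compound 2 `Cc1nc(S(C)(=O)=O)ccc1Oc1ncnc(OC2CCN(C(=O)O[C@H](C)CF)CC2)c1F` — 1520 nM
compound 3 `Cc1nc(S(C)(=O)=O)ccc1Oc1ncnc(OC2CCN(C(=O)O[C@@H](C)CF)CC2)c1F` — not yet measured

In a functional assay on isolated protein for inhibition of Glucose-dependent insulinotropic receptor (Rattus norvegicus), read by HTRF and cAMP accumulation (a higher number here means that more compound is needed for the effect, a lower number that less compound is needed), compound 1 gives 167 nM and compound 2 gives 1520 nM. Within the data shown here, compound 2 therefore stands highest of the two measured numbers, and its only neighbour is compound 1, reached by the step of a 9.1-fold higher number from compound 1 to compound 2 (0.96 log units; beyond the scatter). Compound 3 differs from compound 2 as follows: the two compounds have the same atoms and bonds and differ only in configuration as drawn: 1 of 1 stereo elements differ; a stereocentre at a saturated chain carbon is drawn R in compound 2 and S in compound 3. Among the measured compounds shown here, none of the measured steps bears on a change of configuration alone; the single step that exists, a 9.1-fold higher number from compound 1 to compound 2 (0.96 log units; beyond the scatter), exchanges the whole group on the oxygen next to a carbonyl group and carries no information about which drawing of the stereocentre is the more potent one. The direction of the coming step is thus open, and the number of compound 1 marks how far a return could plausibly go. Compound 3 is estimated at 700 nM, with a range from 150 nM to 3500 nM. That estimate amounts to an expected step of a 2.2-fold lower number from compound 2 to compound 3 (0.34 log units; beyond the scatter), stated with low confidence.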

Compound 3, half-maximal effective concentration: 1680 nM
Estimate against measurement, compound 3: 2.4-fold (0.38 log units) below, and the stated range covers the measured number.
By their numbers in this assay, from the lowest: compound 1; then compounds 2 and 3 (each within the scatter of the next).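

In this assay the two drawings of the stereocentre on the 1-(fluoromethyl)ethyl group cannot be told apart (a 1.1-fold higher number from compound 2 to compound 3 (0.04 log units; within the scatter)). Among these compounds, the earlier compounds could not show this, since their only step exchanged the whole group on the oxygen. That exchange now reads the same way for the other drawing (a 10-fold higher number from compound 1 to compound 3 (1.00 log units; beyond the scatter)), so the gap to cyclobutyl does not depend on the configuration drawn, and the comparison of the two drawings rests on one fact: the fact that compounds 2 and 3 differ only in the configuration as drawn

Whether that gap belongs to the fluorine or to the open chain remains unsettled. An isopropyl group or a cyclopentyl group on the same oxygen would bear on that question.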